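Chloro for methyl on the sulfonyl aryl ring of compound 1

The source may hold more compounds than are shown below. What is called first, only, known or untested is meant among the compounds shown, and "the series" means these compounds.

The series shares one core carrying an aryl sulfonamide. Compound 1 `CCN(CC)CCNC(=O)Nc1nc2ccc(-c3cnc(OC)c(NS(=O)(=O)c4ccc(C)cc4)c3)cn2n1` gives 410 nM in a functional assay on MCF7 cells (Homo sapiens) for cytotoxicity, read by MTT assay, with a stated time of 72 h (a higher number here means a weaker inhibitor, a lower number a stronger inhibitor), the second highest of the three numbers; compound 3 `COc1ncc(-c2ccc3nc(NC(=O)NCC(=O)N4CCOCC4)nn3c2)cc1NS(=O)(=O)c1ccc(F)cc1` sits nearest at 630 nM, within the scatter, and compound 2 `CNC(=O)Nc1nc2ccc(-c3cnc(OC)c(NS(=O)(=O)c4ccc(F)cc4)c3)cn2n1` at 250 nM, also within the scatter of compound 1. Among the compounds with values here, the only single-point step measured, a 2.5-fold higher number from compound 2 to compound 3 (0.40 log units; beyond the scatter), concerns the urea side and not the sulfonyl aryl ring, so it does not bear on the change at hand. Compound 4 `CCN(CC)CCNC(=O)Nc1nc2ccc(-c3cnc(OC)c(NS(=O)(=O)c4ccc(Cl)cc4)c3)cn2n1` differs from compound 1 by chloro in place of methyl on an aromatic carbon. Compound 2 carries fluoro at the same place but differs from compound 1 in a second place too, so its value speaks only loosely; what the two values show is that a halogen there coexists with a number in the same region. Within the data shown here, with no directly relevant step, compound 4 is expected to land close to compound 1, a 1.0-fold lower number from compound 1 to compound 4 (0.01 log units; within the scatter), within the scatter. The estimate for compound 4 in this assay is 400 nM, between 150 nM and 1000 nM.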

Compound 4, half-maximal inhibitory concentration: 680 nM
For compound 4 the middle estimate is 1.7-fold (0.23 log units) below the measured one; measured number inside the range.
By their numbers in this assay, from the lowest: compounds 2, 1, 3 and 4 (each within the scatter of the next, the first and the last beyond it).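

In this assay, a 1.7-fold higher number from compound 1 to compound 4 (0.22 log units; within the scatter) is the only step shown that changes the sulfonyl aryl ring alone, with the urea side held fixed. It lies within the scatter, so at this aromatic carbon, para to a large group, chloro in place of methyl gives no readable change in this assay. The 4-chlorophenyl and 4-methylphenyl sulfonamides therefore cannot be told apart here, and nothing available explains the step further.

The compounds shown leave open whether a group unlike these two at the same carbon, such as an amine, a nitrile or a carboxylic acid, would move the number beyond the scatter. They also leave open whether the chloro for methyl exchange reads the same with a urea side other than that of compound 1.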